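Replacing the Oxazolyl Pyrrolidinone with 4-Fluorophenyl

A few compounds are considered here, and "the series" means these few. Any claim that something is new, unique, unknown or untested is made for them only; others in the source may bear on it.

In a toxicity assay on HepG2 2.2.15 cells (Homo sapiens) for cytotoxicity, read by CellTiter-Glo (a lower number here means that less compound is tolerated, a higher number that more compound is tolerated), compound 1 `O=C1NC(c2ccccc2)CN1c1cnn2c1CN(C(=O)Nc1cc(F)c(F)c(F)c1)C(C1CC1)C2` gives 38500 nM. Compound 2 `O=C1CC(c2ncco2)CN1c1cnn2c1CN(C(=O)Nc1cc(F)c(F)c(F)c1)C(C1CC1)C2` gives > 200000 nM, which is a limit and not a number. Its standing on the numbers is the limit of > 200000 nM in this assay, at which 1 of the 2 values shown sits. Going by the values given here, the one measured step, an at least 5.1-fold higher number from compound 1 to compound 2 (0.71 log units; beyond the scatter), came with 4-(1,3-oxazol-2-yl)-2-oxopyrrolidin-1-yl in place of 2-oxo-4-phenylimidazolidin-1-yl on an aromatic carbon. Compound 3 `O=C(Nc1cc(F)c(F)c(F)c1)N1Cc2c(-c3ccc(F)cc3)cnn2CC1C1CC1` keeps the shared core but carries 4-fluorophenyl in place of 4-(1,3-oxazol-2-yl)-2-oxopyrrolidin-1-yl on that same aromatic carbon (4-fluorophenyl in place of 4-(1,3-oxazol-2-yl)-2-oxopyrrolidin-1-yl on an aromatic carbon). That single step shows that a change at this place can move the result beyond the scatter. Compound 3 gives up the group that compound 2 gained there, so a lower number is expected, at least as large as that step and not within the scatter. The expected change is an at least 5.0-fold lower number from compound 2 to compound 3 (0.69 log units; beyond the scatter). For compound 3 the estimate is 40000 nM, with an expected range of 12000 nM to 130000 nM.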

Compound 3, half-maximal cytotoxic concentration: 38500 nM
Compound 3: the middle estimate sits 1.0-fold (0.02 log units) above what was measured, within the range that was stated.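

In this assay, a second replacement on this aromatic carbon moves the result beyond the scatter, an at least 5.1-fold lower number from compound 2 to compound 3 (0.71 log units; beyond the scatter), so the higher number does not persist once 4-fluorophenyl enters there. The groups 2-oxo-4-phenylimidazolidin-1-yl and 4-fluorophenyl read alike at this place, with no change at the digits printed from compound 1 to compound 3 (within the scatter), and among the three groups shown only 4-(1,3-oxazol-2-yl)-2-oxopyrrolidin-1-yl stands apart. The full size of that difference remains unknown, as compound 2 gives a limit and not a number: the limit of > 200000 nM in this assay, at which 1 of the 3 values shown sits.

Going by these compounds, the oxazole and the pyrrolidinone leave together in the step to 4-fluorophenyl, so it remains open which of the two goes with the higher number. Also open, on these data alone, is how an amine or a carboxylic acid on this aromatic carbon would read in this assay.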